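The source may report more compounds than this note shows. Statements on the series, on what has been measured and on what is new or still open speak of the compounds shown alone.

Compound 2 `NC(=O)[C@@H](CCC(F)(F)F)N(C[C@@H]1CCCCO1)S(=O)(=O)c1ccc(Cl)cc1` gives 15.4 10^-6 cm/s in an ADME assay on MDCKII-LE cells (Canis lupus familiaris) for permeability, read by transwell migration, in the apical to basolateral direction (on this read-out higher numbers stand for higher permeability and lower numbers for lower permeability), and it stands alongside compound 1 `NC(=O)[C@@H](CCC(F)(F)F)N(C[C@H]1CCCCO1)S(=O)(=O)c1ccc(Cl)cc1`, which gives 13.4 10^-6 cm/s, the two within the scatter of each other. Compound 3 `NC(=O)[C@@H](CCC(F)(F)F)N(C[C@@H]1CCCO1)S(=O)(=O)c1ccc(Cl)cc1` has not yet been measured; it carries oxolan-2-yl in place of oxan-2-yl on a saturated chain carbon bound to a sulfonamide nitrogen. Among the measured compounds shown here, the only measured step, a 1.1-fold higher number from compound 1 to compound 2 (0.06 log units; within the scatter), rests on (the fact that compounds 1 and 2 differ only in the configuration as drawn), a change in configuration alone, so no measured step bears on replacing a six-membered non-aromatic ring with a five-membered one. Compound 3 is therefore expected to give 13 10^-6 cm/s, between 7 10^-6 cm/s and 25 10^-6 cm/s, a step of a 1.2-fold lower number from compound 2 to compound 3 (0.07 log units; within the scatter) that stays within the scatter.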

Compound 3, apparent permeability: 22.4 10^-6 cm/s
Beside the measured number, compound 3's estimate is 1.7-fold (0.24 log units) below it; measured number inside the range.
By their numbers in this assay, from the lowest: compounds 1, 2 and 3 (each within the scatter of the next).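

Replacing oxan-2-yl with oxolan-2-yl on a saturated chain carbon bound to a sulfonamide nitrogen is the first change of ring size shown, and in this assay it gives a 1.5-fold higher number from compound 2 to compound 3 (0.16 log units; within the scatter) and a 1.7-fold higher number from compound 1 to compound 3 (0.22 log units; within the scatter) as its two steps. Both lie within the scatter, so the numbers do not separate the five-membered ring from the six-membered one at this position. Nothing shown gives a cause for this result.

Still open, from the compounds shown here alone, is whether an amine or a carboxylic acid at this position would move the number beyond the scatter. Going by these compounds, the opposite configuration of the oxolan-2-yl ring also remains open.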